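The source may report more compounds than this note shows. Statements on the series, on what has been measured and on what is new or still open speak of the compounds shown alone.

Compound 1 `CC(C)(C)OC(=O)N1CCN(C(=S)SCc2cn(-c3ccccc3F)nn2)CC1` is the weakest of the three compounds measured in a functional assay on MGC-803 cells (Homo sapiens) for inhibition, read by MTT assay, with a stated time of 72 h (a lower number here means a stronger inhibitor, a higher number a weaker inhibitor), where compound 1 gives 119000 nM. The nearest number belongs to compound 3 `S=C(SCc1cn(Cc2ccccc2Cl)nn1)N1CCNCC1`, which gives 45200 nM in this assay, and the furthest to compound 2 `O=C(OCc1ccccc1)N1CCN(C(=S)SCc2cn(Cc3ccc(Cl)c(Cl)c3)nn2)CC1`, which gives 7140 nM. Compound 4 `Cc1ccc(Cn2cc(CSC(=S)N3CCN(C(=O)OC(C)(C)C)CC3)nn2)cc1` has not been measured; it differs from compound 1 in one place, (4-methylbenzyl in place of 2-fluorophenyl on an aromatic nitrogen), with a 4-methylbenzyl entering on the aromatic nitrogen. Compounds 2 and 3 also carry a benzyl-type group there and show lower numbers than compound 1, though they differ elsewhere too. The step from compound 1 to compound 4 is therefore expected to go toward a lower number, beyond the scatter, a 3.0-fold lower number from compound 1 to compound 4 (0.47 log units; beyond the scatter). Compound 4 is estimated at 40000 nM, within 12000 nM to 120000 nM.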

Compound 4, half-maximal inhibitory concentration: 3490 nM
Compound 4: middle estimate off by 11-fold (1.06 log units), on the high side; the whole stated range lies above it.
By their numbers in this assay, from the lowest: compound 4; then compound 2; then compound 3; then compound 1.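

Holding the rest of compound 1 fixed, the change of 2-fluorophenyl to 4-methylbenzyl on the aromatic nitrogen gives a large step in this assay (a 34-fold lower number from compound 1 to compound 4 (1.53 log units; beyond the scatter)). Within the data shown here, this position alone can therefore move the number far beyond the scatter, which the earlier compounds, differing in several places, could not show. No evidence given here bears on why the step is so large. Still open, as far as these compounds go, is how much of it belongs to the carbon link and how much to the methyl group. Plain benzyl, 4-methylphenyl or 4-methoxybenzyl on this nitrogen would help separate the two.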